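Rearranging the Side Chain of Compound 2

The source may report more compounds than this note shows. Statements on the series, on what has been measured and on what is new or still open speak of the compounds shown alone.

In a functional assay on A549 cells (Homo sapiens) for antiproliferative activity, read by MTT assay, with a stated time of 48 h (a higher number here means a weaker inhibitor of growth, a lower number a stronger inhibitor of growth), compound 1 (`Cc1ccc(-c2cnc(N(Cc3ccc(C(=O)NO)cc3)CC(C)C)s2)cc1`) gives 20400 nM and compound 2 (`Cc1ccc(OCCCN(Cc2ccc(C(=O)NO)cc2)c2ncc(-c3ccc(C)cc3)s2)cc1`) gives 32500 nM, so these two values lie within the scatter of each other. Compound 3 (`Cc1ccc(-c2cnc(N(CCCCOc3ccccc3)Cc3ccc(C(=O)NO)cc3)s2)cc1`) holds the same atoms as compound 2, joined differently: phenoxymethyl in place of 4-methylphenoxy on a saturated chain carbon, three bonds along the chain from a nitrogen on an aromatic ring. Among the measured compounds shown here, the only measured step, a 1.6-fold higher number from compound 1 to compound 2 (0.20 log units; within the scatter), exchanged a side group and stayed within the scatter. No step beyond the scatter is therefore expected in this assay. The expected step is small, a 1.2-fold lower number from compound 2 to compound 3 (0.06 log units; within the scatter). Compound 3 is estimated at 28000 nM, with an expected range of 13000 nM to 60000 nM.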

Compound 3, concentration for 50% growth inhibition: 14200 nM
Compound 3: middle estimate off by 2.0-fold (0.29 log units), on the high side; low and high end bracket the measured number.
By their numbers in this assay, from the lowest: compounds 3, 1 and 2 (each within the scatter of the next, the first and the last beyond it).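

Among the compounds shown here, exchanging 3-(4-methylphenoxy)propyl for 4-phenoxybutyl keeps every atom yet gives, in this assay, a 2.3-fold lower number from compound 2 to compound 3 (0.36 log units; beyond the scatter), a modest change and the first step here beyond the scatter, so how these atoms are joined has some bearing at this position. By contrast, 3-phenoxypropyl in place of isopropyl gives a 1.4-fold lower number from compound 1 to compound 3 (0.16 log units; within the scatter), so that larger exchange shows no real change. Nothing available explains the difference between the two isomers.

Still open, as far as these compounds go, is whether a longer chain would move the number further, and whether an amine or a carboxylic acid at the chain end would do so.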